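One More Ring Hetero Atom on an Active Amide

The compounds below may be only part of what the source reports. "The series", "measured", "known", "first", "only" and "open" are said of these compounds alone.

In a functional assay on A2780 cells (Homo sapiens) for inhibition, read by sulforhodamine B assay, with a stated time of 72 h (on this read-out higher numbers stand for weaker inhibition and lower numbers for stronger inhibition), compound 1 (`Cc1ccccc1S(=O)(=O)c1ccc(CNC(=O)c2cc3cnccc3[nH]2)cc1`) gives 13 nM and compound 3 (`O=C(NCc1ccc(S(=O)(=O)c2ccccc2)cc1)c1cc2ccncc2s1`) gives 14 nM so these two sit within the usual scatter of each other. Compound 2 (`O=C(NCc1ccc(S(=O)(=O)c2ccccc2)cc1)c1ccc2ncncc2c1`) reads > 10000 nM in this assay and this is a limit of the assay, not a number. Compound 4 (`O=C(NCc1ccc(S(=O)(=O)c2ccccc2)cc1)c1nc2ccncc2s1`) awaits measurement and differs from compound 3 in one place (a group of 9 heavy atoms (6 carbon, 2 nitrogen, 1 sulfur; one five-membered aromatic ring with 2 hetero atoms, one six-membered aromatic ring with 1 hetero atom) in place of a group of 9 heavy atoms (7 carbon, 1 nitrogen, 1 sulfur; one five-membered aromatic ring with 1 hetero atom, one six-membered aromatic ring with 1 hetero atom), on a carbonyl carbon) with one more hetero atom in the five-membered aromatic ring. Among the measured compounds shown here, no measured pair shows this change, so, starting from compound 3 at 14 nM only a modest move toward weaker inhibition in this assay is expected, with a wide margin. The expected step is a 2.1-fold higher number from compound 3 to compound 4 (0.33 log units; beyond the scatter) in size. Compound 4 is estimated at 30 nM and expected to land between 6 nM and 200 nM.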

Compound 4, half-maximal inhibitory concentration: > 10000 nM
Compound 4 gave a limit, no number; the forecaster's own chance of this, stated with the estimate: 5%; at least 330-fold (2.52 log units) between middle value and limit.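

In this assay, adding one hetero atom to the five-membered aromatic ring, with the heavy-atom count unchanged, gives an at least 710-fold higher number from compound 3 to compound 4 (2.85 log units; beyond the scatter). Among the compounds shown here, this is the first one-place comparison here, and it shows that activity can depend on a single ring atom of the group on the carbonyl carbon. The reading for compound 4 is a limit of the assay and not a number, so the true size of the step stays unknown: the limit of > 10000 nM in this assay, at which 2 of the 4 values shown sit.

On these data alone, whether the loss comes from the added ring nitrogen alone remains open. A methyl group or a chlorine on that ring carbon of compound 3, or oxygen in place of its ring sulfur, could help to test this.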